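This account rests on a few compounds, and the source may have more. Where it says the series, first, only, none or still open, it means among the compounds named here.

Measured compounds:
- compound 1 `CCCCc1c(F)c(N)c2c(=O)cc(-c3ccc(N)c(F)c3)oc2c1F` – in a functional assay on HeLa cells (Homo sapiens) for cytotoxicity, read by neutral red uptake, with a stated time of 3 days (on this read-out higher numbers stand for weaker inhibition and lower numbers for stronger inhibition), compound 1 reaches only the assay limit, > 100000 nM.
- compound 2 `CCCCCCc1c(F)c(N)c2c(=O)cc(-c3ccc(N)c(F)c3)oc2c1F` – compound 2 gives 21000 nM.
- compound 3 `Nc1ccc(-c2cc(=O)c3c(N)c(F)c(CO)c(F)c3o2)cc1F` – compound 3 gives 24000 nM.

Compound 3 and compound 2 are within the scatter of each other a 1.1-fold higher number from compound 2 to compound 3 (0.06 log units; within the scatter), while compound 1 shows only a limit (the limit of > 100000 nM in this assay, at which 1 of the 3 values shown sits). Compound 4 `Nc1ccc(-c2cc(=O)c3c(N)c(F)c(Cl)c(F)c3o2)cc1F` differs from compound 3 by chloro in place of hydroxymethyl on an aromatic carbon. Within the data shown here, no measured step swaps these two groups; the nearest comparisons are an at least 4.1-fold lower number from compound 1 to compound 3 (0.61 log units; beyond the scatter) and a 1.1-fold higher number from compound 2 to compound 3 (0.06 log units; within the scatter), which exchange a chain for a hydroxy and move the number at most modestly. A change of similar or smaller size is therefore expected, with no clear direction, so compound 4 is estimated at 20000 nM (range 5000 nM to 100000 nM), an expected step of a 1.2-fold lower number from compound 3 to compound 4 (0.08 log units; within the scatter).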

Compound 4, half-maximal inhibitory concentration: > 100000 nM
Compound 4 was reported as a limit; the forecaster's own chance of this, stated with the estimate: 25%; middle value at least 5.0-fold (0.69 log units) away from the limit.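

In this assay, this position proves sensitive to a small group as well as to a chain: chloro in place of hydroxymethyl gives an at least 4.1-fold higher number from compound 3 to compound 4 (0.61 log units; beyond the scatter), and chloro in place of hexyl gives an at least 4.7-fold higher number from compound 2 to compound 4 (0.67 log units; beyond the scatter). So a short hydroxymethyl group and a long hexyl chain both give a measurable number here, whereas chloro does not. The step between compounds 1 and 4 cannot be read, since each of them shows only a limit: the limit of > 100000 nM in this assay, at which 2 of the 4 values shown sit.

On these data alone, whether an amine or a carboxylic acid on this aromatic carbon would give a measurable number remains open. So does the outcome with a chain longer than hexyl.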